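Lengthening the Alkoxy Chain on a Urea Antagonist

The compounds below may be only part of what the source reports. "The series", "measured", "known", "first", "only" and "open" are said of these compounds alone.

Measured so far:
compound 1, `CCCN(CCC)c1nc(C(F)(F)F)ccc1CNC(=O)Nc1cccc2[nH]c(=O)ccc12`: 5.21 nM
compound 2, `CCCCCOc1nc(C(F)(F)F)ccc1CNC(=O)Nc1cccc2[nH]c(=O)ccc12`: 2.72 nM

Both compounds were tested in an assay on HEK cells for antagonist activity at transient receptor potential cation channel subfamily V member 1 (Homo sapiens), read by FLIPR; on this read-out lower numbers stand for stronger inhibition and higher numbers for weaker inhibition. Compound 1 gives 5.21 nM, and compound 2 gives 2.72 nM, the lowest of the two numbers, though the single shown step, a 1.9-fold lower number from compound 1 to compound 2 (0.28 log units; within the scatter), lies within the scatter, so the two compounds cannot be told apart on these numbers.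

Compound 3, `CCCCCCOc1nc(C(F)(F)F)ccc1CNC(=O)Nc1cccc2[nH]c(=O)ccc12`, has not yet been measured in this assay. It differs from compound 2 by methyl in place of hydrogen on a saturated chain carbon, five bonds along the chain from an oxygen on an aromatic ring, so the pentyloxy chain of compound 2 becomes a hexyloxy chain. Among the compounds with values here, no measured step covers a change of this kind: the only known step swaps a dipropylamino group for a pentyloxy group and stays within the scatter. With nothing that speaks for a shift in either direction, compound 3 is expected to land close to compound 2, and the estimated step of a 1.0-fold lower number from compound 2 to compound 3 (0.02 log units; within the scatter) is expected to stay within the scatter. Compound 3 is therefore estimated at 2.6 nM in this assay, with a range from 1 nM to 7 nM.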

Compound 3, half-maximal inhibitory concentration: 3.19 nM
For compound 3 the middle estimate is 1.2-fold (0.09 log units) below the measured one; measured number inside the range.
By their numbers in this assay, from the lowest: compounds 2, 3 and 1 (each within the scatter of the next).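

In this assay, lengthening the pentyloxy chain to a hexyloxy chain, with the methyl entering on a saturated chain carbon, five bonds along the chain from an oxygen on an aromatic ring, gives a 1.2-fold higher number from compound 2 to compound 3 (0.07 log units; within the scatter) and so produces no change that can be distinguished from the scatter. This position therefore accepts one more chain carbon without a detectable cost in this read-out. Replacing dipropylamino with hexyloxy on an aromatic carbon gives a 1.6-fold lower number from compound 1 to compound 3 (0.21 log units; within the scatter), so the hexyloxy compound, like the pentyloxy one, cannot be told apart from the dipropylamino compound, and no measurement available here bears on why these values lie so close together.

The compounds shown do not reveal how much further the chain can grow, for example whether a longer chain such as octyloxy would also stay within the scatter of compound 2. They also leave open whether this position would accept a chain carrying an amine or a carboxylic acid, or a shorter chain such as ethoxy.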